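A few compounds are considered here, and "the series" means these few. Any claim that something is new, unique, unknown or untested is made for them only; others in the source may bear on it.

Compound 1 `CC(=O)N1CCC(Sc2c[nH]c3ccc(Cl)cc23)CC1` is one of two compounds examined so far in a functional assay on the whole organism with Mus musculus as the target, in the hot plate test (on this read-out lower numbers stand for an effect already at smaller amounts and higher numbers for an effect only at larger amounts of compound), where compound 1 gives 3.8 mg/kg. Among the compounds with values here, its only neighbour is compound 2 `CC(=O)N1CCC(Sc2c[nH]c3ccc(Br)cc23)CC1`, which in this assay gives 2.8 mg/kg; the step of a 1.4-fold lower number from compound 1 to compound 2 (0.13 log units; within the scatter) does not separate the two beyond the scatter, so compound 1 stands level with the one other number in hand rather than apart from it.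

Compound 3 `CCN1CCC(Sc2c[nH]c3ccc(Cl)cc23)CC1` arises from compound 1 through (ethyl in place of acetyl on an amine nitrogen in a ring). Within the data shown here, the single measured step, a 1.4-fold lower number from compound 1 to compound 2 (0.13 log units; within the scatter), concerns a halogen exchange on an aromatic carbon and leaves the amine nitrogen untouched, so no measured step bears on the change that leads to compound 3. With nothing to lean on, the expectation for compound 3 is drawn from compound 1 alone: no step beyond the scatter in either direction, but with a wide allowance for the untested position. The expected step from compound 1 to compound 3 is a 1.1-fold lower number from compound 1 to compound 3 (0.04 log units; within the scatter). Compound 3 is therefore estimated at 3.5 mg/kg, within a range from 1.2 mg/kg to 10 mg/kg.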

Compound 3, dose for half-maximal effect: 33.3 mg/kg
Estimate against measurement, compound 3: 9.5-fold (0.98 log units) below, and the stated range ends below it.
By their numbers in this assay, from the lowest: compounds 2 and 1 (each within the scatter of the next); then compound 3.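

The step of an 8.8-fold higher number from compound 1 to compound 3 (0.94 log units; beyond the scatter) in this assay shows that this position, the amine nitrogen in the ring, responds to a change of group, whereas the bromo for chloro exchange on the aromatic carbon, a 1.4-fold lower number from compound 1 to compound 2 (0.13 log units; within the scatter), stayed within the scatter. Of the two changes seen so far, only ethyl in place of acetyl moves the number beyond the scatter, and it moves it towards effect only at larger amounts of compound, so among these compounds the acetyl form is the one with the lower number. The change removes a carbonyl and its hydrogen-bond acceptor and also shortens the group by one heavy atom, and nothing available indicates why the number rises or which of these differences matters.

The compounds shown leave open how a propanoyl, a methanesulfonyl or a carbamoyl group on this nitrogen would compare, and whether a plain methyl or a longer alkyl chain would stand with ethyl. They also leave open whether ethyl in place of acetyl would give a step of similar size on the bromo compound 2.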